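Cyclopropylmethyl in place of cyclopentyl in compound 1

The compounds below may be only part of what the source reports. "The series", "measured", "known", "first", "only" and "open" are said of these compounds alone.

Of the compounds shown here, two have measured values so far. In a functional assay on K562 cells (Homo sapiens) for inhibition, read by trypan blue exclusion, with a stated time of 72 h (on this read-out higher numbers stand for weaker inhibition and lower numbers for stronger inhibition), compound 1 (`O=c1c(S(=O)(=O)c2ccc(F)cc2F)cc2cnc(Nc3ccc4[nH]ccc4c3)nc2n1C1CCCC1`) gives 5000 nM, the lower of the two numbers. Compound 2 (`Cn1c(=O)c(S(=O)(=O)c2ccc(Cl)cc2)cc2cnc(Nc3cnc4ccccc4c3)nc21`) gives 15000 nM, and this gap lies beyond the scatter. Within the data shown here, the two compounds differ in more than one place, so their gap cannot be assigned to any single group, and the series offers no measured single-place step for calibration.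

Compound 3 (`O=c1c(S(=O)(=O)c2ccc(F)cc2F)cc2cnc(Nc3ccc4[nH]ccc4c3)nc2n1CC1CC1`) keeps the core of compound 1 and its (2,4-difluorophenyl)sulfonyl group, with cyclopropylmethyl in place of cyclopentyl on an aromatic nitrogen. The only direct anchor for this change is compound 1 at 5000 nM, so no direction can be favoured with any confidence. The expected result in this assay is no step beyond the scatter, and the estimated move is a 1.2-fold higher number from compound 1 to compound 3 (0.08 log units; within the scatter). For compound 3 the estimated value is 6000 nM, with an expected range from 2500 nM to 15000 nM.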

Compound 3, half-maximal inhibitory concentration: 1000 nM
Compound 3: middle estimate off by 6.0-fold (0.78 log units), on the high side; the measured number lies below the stated range.
By their numbers in this assay, from the lowest: compound 3; then compound 1; then compound 2.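

Among these compounds, the group on this aromatic nitrogen is the first place with a measured single-place step: in this assay, cyclopropylmethyl in place of cyclopentyl gives a 5.0-fold lower number from compound 1 to compound 3 (0.70 log units; beyond the scatter). With the (2,4-difluorophenyl)sulfonyl group and the rest of the core of compound 1 held fixed, this one exchange moves the number beyond the scatter, so the nitrogen substituent alone can change the read-out in this assay, and in this pair the change favours the group with the three-membered ring. No supporting measurement is available to explain the step.

This single pair does not separate the loss of the five-membered ring from the arrival of the three-membered ring on its carbon link, a question that cyclopropyl directly on the nitrogen, cyclopentylmethyl or an open isobutyl chain could address. It also leaves open whether the step carries over to other sulfonyl groups, such as the 4-chlorophenylsulfonyl group of compound 2, and how a nitrogen substituent carrying an amine, such as 2-(dimethylamino)ethyl, would read.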